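This account rests on a few compounds, and the source may have more. Where it says the series, first, only, none or still open, it means among the compounds named here.

Compound 3 `COc1ccc(Nc2nc(SCc3ccc(C(F)(F)F)cc3)nc3ccccc23)cc1` stands, in a functional assay on MGC-803 cells (Homo sapiens) for cytotoxicity, read by MTT assay, with a stated time of 72 h (a higher number here means a weaker inhibitor, a lower number a stronger inhibitor), at the higher of the two numbers in hand, with 13800 nM; compound 1 `CCCCCCNc1nc(SCc2ccc(C(F)(F)F)cc2)nc2ccccc12` gives 13100 nM, and the step of a 1.1-fold higher number from compound 1 to compound 3 (0.02 log units; within the scatter) lies within the scatter. Compound 2 `FC(F)(F)c1ccc(CSc2nc(Nc3ccccc3Cl)c3ccccc3n2)cc1` is reported only as a limit, > 50000 nM, as recorded in the limit of > 50000 nM in this assay, at which 1 of the 3 values shown sits. Compound 4 `COc1cc(Nc2nc(SCc3ccc(C(F)(F)F)cc3)nc3ccccc23)cc(OC)c1` differs from compound 3 by 3,5-dimethoxyphenyl in place of 4-methoxyphenyl on a nitrogen on an aromatic ring. Two measured steps already change the group on that nitrogen: an at least 3.6-fold lower number from compound 2 to compound 3 (0.55 log units; beyond the scatter) was beyond the scatter, while a 1.1-fold higher number from compound 1 to compound 3 (0.02 log units; within the scatter) was not, so such swaps here can move the number or leave it alone. With nothing more to go on, the step of a 1.2-fold lower number from compound 3 to compound 4 (0.06 log units; within the scatter) is expected to remain within the scatter. Compound 4 is therefore estimated at 12000 nM, between 4000 nM and 40000 nM.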

Compound 4, half-maximal inhibitory concentration: 8580 nM
Beside the measured number, compound 4's estimate is 1.4-fold (0.15 log units) above it, and the stated range covers the measured number.
By their numbers in this assay, from the lowest: compounds 4, 1 and 3 (each within the scatter of the next). At a limit, above all of these: compound 2.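

In this assay, the steps of a 1.6-fold lower number from compound 3 to compound 4 (0.21 log units; within the scatter) and a 1.5-fold lower number from compound 1 to compound 4 (0.18 log units; within the scatter) show that 3,5-dimethoxyphenyl on this nitrogen reads alongside 4-methoxyphenyl and hexyl, so adding a second methoxy group and shifting both groups to the 3 and 5 positions leaves the number unresolved from the others. Within the data shown here, only the step to the 2-chlorophenyl compound stands apart, an at least 5.8-fold lower number from compound 2 to compound 4 (0.76 log units; beyond the scatter). Compound 2 remains a limit of the assay: the limit of > 50000 nM in this assay, at which 1 of the 4 values shown sits.

The compounds shown leave open how a benzyl group or a shorter alkyl chain on this nitrogen would read. They also leave open whether the result for compound 2 belongs to the chlorine itself or to where it sits.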